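Sulfonyl sulfur substituents and inhibition of DU-145 cells

The source may report more compounds than this note shows. Statements on the series, on what has been measured and on what is new or still open speak of the compounds shown alone.

compound 1 `Cn1c(=O)c(S(=O)(=O)Cc2ccc(F)cc2)cc2cnc(Nc3ccc4[nH]ccc4c3)nc21` gives 30000 nM
compound 2 `Cn1c(=O)c(S(=O)(=O)c2ccc(F)cc2[N+](=O)[O-])cc2cnc(Nc3ccc4[nH]ccc4c3)nc21` gives 1500 nM

In a functional assay on DU-145 cells (Homo sapiens) for inhibition, read by trypan blue exclusion, with a stated time of 72 h (on this read-out lower numbers stand for stronger inhibition and higher numbers for weaker inhibition), compound 2 at 1500 nM holds the lower of the two numbers. Within the data shown here, the only measured step of a 20-fold lower number from compound 1 to compound 2 (1.30 log units; beyond the scatter) is large and beyond the scatter, and it also changes the group on the sulfonyl sulfur. Compound 3 `Cn1c(=O)c(S(=O)(=O)Nc2ccc(F)cc2F)cc2cnc(Nc3ccc4[nH]ccc4c3)nc21` brings (2,4-difluorophenyl)amino in place of 4-fluoro-2-nitrophenyl on a sulfonyl sulfur with (2,4-difluorophenyl)amino in place of 4-fluoro-2-nitrophenyl on a sulfonyl sulfur. That one step fixes no direction firmly, so only a moderately higher number is expected, estimated as a 2.7-fold higher number from compound 2 to compound 3 (0.43 log units; beyond the scatter) for now. For compound 3 the estimated value in this assay is 4000 nM with a range from 700 nM to 20000 nM overall.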

Compound 3, half-maximal inhibitory concentration: 5000 nM
Compound 3: the middle estimate sits 1.3-fold (0.10 log units) below what was measured, within the range that was stated.
By their numbers in this assay, from the lowest: compound 2; then compound 3; then compound 1.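

At the sulfonyl sulfur, an aryl group attached through nitrogen keeps measurable activity in this assay: (2,4-difluorophenyl)amino in place of 4-fluoro-2-nitrophenyl gives a 3.3-fold higher number from compound 2 to compound 3 (0.52 log units; beyond the scatter) and, in place of 4-fluorobenzyl, gives a 6.0-fold lower number from compound 1 to compound 3 (0.78 log units; beyond the scatter) at this position. The entering group also brings a hydrogen-bond donor, but with the aryl substituents changing too, these compounds cannot isolate its contribution. Nothing available explains either step.

Open, on these data alone, is how a morpholine or a simple alkyl chain on the sulfonyl sulfur would compare. Also open, as far as these compounds go, is whether a carboxylic acid on the aryl ring would shift the number in either direction.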